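The source may hold more compounds than are shown below. What is called first, only, known or untested is meant among the compounds shown, and "the series" means these compounds.

Compound 3 `Nc1nc(-c2ccco2)nc2sc(CN3CCC(F)CC3)cc12` carries a 4-fluoropiperidin-1-yl group on the saturated chain carbon bound to an aromatic carbon of the shared core. In an assay on CHO-K1 cells for antagonist activity at adenosine receptor A1 (Homo sapiens), read by a beta-galactosidase reporter, with stated times of 15 min and 6 h (a higher number here means a weaker inhibitor, a lower number a stronger inhibitor), compound 3 gives 740 nM. Among the three measured compounds this is the middle number: compound 1 `Nc1nc(-c2ccco2)nc2sc(CN3CCCC3)cc12`, with pyrrolidin-1-yl in that place, gives 6430 nM, and compound 2 `Nc1nc(-c2ccco2)nc2sc(CN3CC=CCC3)cc12` gives 150 nM. The steps are an 8.7-fold lower number from compound 1 to compound 3 (0.94 log units; beyond the scatter), a 43-fold lower number from compound 1 to compound 2 (1.63 log units; beyond the scatter) and a 4.9-fold higher number from compound 2 to compound 3 (0.69 log units; beyond the scatter).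

Compound 4 `Nc1nc(-c2ccco2)nc2sc(CN3CCC(F)(F)CC3)cc12` differs from compound 3 by fluoro in place of hydrogen on a saturated ring carbon. Among the compounds with values here, the only measured step of a related kind is the single fluoro entering the six-membered ring, a 4.9-fold higher number from compound 2 to compound 3 (0.69 log units; beyond the scatter), which raised the number by a modest amount. A second fluoro at the same saturated ring carbon is expected to act in a similar direction but with less certainty, so for compound 4 a step of a 1.8-fold higher number from compound 3 to compound 4 (0.24 log units; within the scatter) is expected in this assay. The estimated value for compound 4 in this assay is 1300 nM, with a likely range from 450 nM to 3800 nM.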

Compound 4, inhibition constant: 2230 nM
The estimate for compound 4 lay 1.7-fold (0.23 log units) below the measured number, within the range that was stated.
By their numbers in this assay, from the lowest: compound 2; then compound 3; then compound 4; then compound 1.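

Within the data shown here, this is the first step in which only a fluoro changes, with the ring otherwise untouched: on the saturated ring carbon, three ring bonds from the ring nitrogen, fluoro in place of hydrogen gives a 3.0-fold higher number from compound 3 to compound 4 (0.48 log units; beyond the scatter) in this assay. It also shows how far the difluoro ring stands from the other two rings, with a 15-fold higher number from compound 2 to compound 4 (1.17 log units; beyond the scatter), while a gap in its favour over pyrrolidin-1-yl remains, with a 2.9-fold lower number from compound 1 to compound 4 (0.46 log units; beyond the scatter). No measurement offered here explains these steps.

The compounds shown leave open where plain piperidin-1-yl, with hydrogen in place of every fluoro, would fall, so the effect of the first fluoro alone stays unknown. They also leave open whether a hydroxyl or a methyl at the same ring carbon would move the number the same way.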